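Swapping a tert-butylphenyl for phenoxy on a quinoline core

This account rests on a few compounds, and the source may have more. Where it says the series, first, only, none or still open, it means among the compounds named here.

Measured compounds:
compound 1 `COc1cccc(CNCCCNc2ccnc3cc(Oc4ccccc4)ccc23)c1O`, 9.28
compound 2 `COc1cccc(CNCCCNc2ccnc3cc(-c4ccc(C(C)(C)C)cc4)ccc23)c1O`, 9.47
compound 3 `CC(C)(C)c1ccc(-c2ccc3c(NCCCNCc4ccco4)ccnc3c2)cc1`, 9.47

In a physicochemical assay for acid dissociation, compound 2 gives 9.47 and compound 1 gives 9.28. The step of a number 0.19 log units lower from compound 2 to compound 1 (within the scatter) goes with the change (phenoxy in place of 4-(tert-butyl)phenyl on an aromatic carbon). Compound 3 differs from compound 2 only by furan-2-yl in place of 2-hydroxy-3-methoxyphenyl on a saturated chain carbon bound to an amine nitrogen, and the step of no change at the digits printed from compound 2 to compound 3 (within the scatter) shows the two stand together. Compound 4 `c1ccc(Oc2ccc3c(NCCCNCc4ccco4)ccnc3c2)cc1` is not yet measured; it differs from compound 3 by phenoxy in place of 4-(tert-butyl)phenyl on an aromatic carbon, the same change as from compound 2 to compound 1, made on a core that itself differs by the change just described.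

For the measured compounds named here, since the one earlier instance of this change gave a number 0.19 log units lower from compound 2 to compound 1 (within the scatter), compound 4 is expected to show a step of about a number 0.19 log units lower from compound 3 to compound 4 (within the scatter). Compound 4 is therefore estimated at 9.28, most likely between 9 and 9.56. This rests on a single earlier pair, so it is an expectation, not a rule.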

Compound 4, acid dissociation constant: 9.28
Compound 4: middle estimate and measured number agree at the digits printed; low and high end bracket the measured number.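

Measured in this assay the swap of 4-(tert-butyl)phenyl for phenoxy gives a number 0.19 log units lower from compound 3 to compound 4 (within the scatter) and matches the step seen on the core of compound 2, while furan-2-yl in place of 2-hydroxy-3-methoxyphenyl gives no change at the digits printed from compound 1 to compound 4 (within the scatter) on the phenoxy side. The change thus carries across these two cores with the same printed step, but that step stays within the scatter, so it shows no real effect of the swap and two pairs make no rule for the series. No measurement here bears on the reason for these numbers.

The compounds shown leave open whether the step would hold on a core with a longer linking chain. Going by these compounds, a carboxylic acid or an amine in place of phenoxy also remains open in this assay as a further test.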